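Working notes: replacing the sulfonyl substituent of compound 1

The source may report more compounds than this note shows. Statements on the series, on what has been measured and on what is new or still open speak of the compounds shown alone.

- compound 1 `COC(=O)NC(=O)c1ccsc1NC(=O)c1ccc(S(=O)(=O)N2CCC(c3ccccc3)CC2)cc1` gives "nd" (no result reported) 
- compound 2 `CCCCNS(=O)(=O)c1ccc(C(=O)Nc2sccc2C(=O)NC(=O)OC)cc1` gives 29.5 ug/mL 

Within the data shown here, in a toxicity assay on Vero cells (Chlorocebus sabaeus) for cytotoxicity, read by MTT assay (on this read-out higher numbers stand for weaker inhibition and lower numbers for stronger inhibition), compound 1 stands without a number, its entry being "nd" (no result reported), so it offers no baseline for the step that follows. The only figure on this series comes from compound 2 at 29.5 ug/mL and it is the sole anchor available here.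

The next compound to be read is compound 3 `COC(=O)NC(=O)c1ccsc1NC(=O)c1ccc(S(=O)(=O)NC2CCC(F)(F)CC2)cc1`. The change (4,4-difluorocyclohexyl)amino in place of 4-phenylpiperidin-1-yl on a sulfonyl sulfur places (4,4-difluorocyclohexyl)amino in place of 4-phenylpiperidin-1-yl on a sulfonyl sulfur.

With no number for compound 1, the size and direction of this step cannot be read from the data. In this assay the level of compound 2 at 29.5 ug/mL is the reference for now, and compound 3 is expected to stay within the scatter of it.

Compound 3 is expected at 35 ug/mL with 12 ug/mL to 100 ug/mL as the estimated range.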

Compound 3, half-maximal inhibitory concentration: 49 ug/mL
The estimate for compound 3 lay 1.4-fold (0.15 log units) below the measured number; the measured number falls inside the stated range.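

In this assay the exchange of butyl for 4,4-difluorocyclohexyl on a sulfonamide nitrogen gives a 1.7-fold higher number from compound 2 to compound 3 (0.22 log units; within the scatter), so at this position the two substituents cannot be told apart on this read-out. As far as these compounds go, the step from 4-phenylpiperidin-1-yl in compound 1 to (4,4-difluorocyclohexyl)amino in compound 3 cannot be read: compound 1 has no number, and the effect of that larger exchange on the sulfonyl sulfur remains unknown. No supporting measurement bears on the level shared by compound 2 and compound 3.

Open, from the compounds shown here alone, is whether a chain longer than butyl, or a sulfonamide nitrogen substituent carrying an amine or a carboxylic acid, would move the number beyond the scatter. Also open, going by these compounds, is how a plain piperidine on the sulfonyl sulfur would read in this assay.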